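Chloro for Nitro: An Expected Flat Step

This account rests on a few compounds, and the source may have more. Where it says the series, first, only, none or still open, it means among the compounds named here.

Compound 1, `COc1ccc(-n2c(Nc3nc(-c4ccc([N+](=O)[O-])cc4)cs3)n[nH]c2=S)cc1`, gives 300 mg/kg in a functional assay on the whole organism (strain Swiss albino) for inhibition, with Mus musculus as the target, with a stated time of 4 h; a lower number here means that less compound is needed, a higher number that more compound is needed for the effect.
Compound 2, `S=c1[nH]nc(Nc2nc(-c3ccccc3)cs2)n1-c1ccccc1`, gives 300 mg/kg.
Compound 3, `Cc1ccccc1-n1c(Nc2nc(-c3ccc([N+](=O)[O-])cc3)cs2)n[nH]c1=S`, gives 300 mg/kg.

Compound 3 stands level with compounds 1 and 2 at the digits shown. Within the data shown here, the only measured single-point step, no change at the digits printed from compound 1 to compound 3 (within the scatter), put 2-methylphenyl in place of 4-methoxyphenyl on an aromatic nitrogen and stayed within the scatter. Compound 4, `Cc1ccccc1-n1c(Nc2nc(-c3ccc(Cl)cc3)cs2)n[nH]c1=S`, differs from compound 3 by chloro in place of nitro on an aromatic carbon. Among the measured compounds shown here, no measured step touches that aromatic carbon, so nothing in hand points to a move in either direction, and with all three measured values sitting together, no step beyond the scatter is expected in this assay. Compound 4 is therefore estimated at 300 mg/kg, within 150 mg/kg to 600 mg/kg. The expected step is no change at the digits printed from compound 3 to compound 4 (within the scatter).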

Compound 4, minimum effective dose: 300 mg/kg
Compound 4: the middle estimate sits on the measured number at the digits printed, and the stated range covers the measured number.
By their numbers in this assay, from the lowest: compounds 1, 2, 3 and 4 (each within the scatter of the next).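

In this assay, replacing 4-nitrophenyl with 4-chlorophenyl gives no change at the digits printed from compound 3 to compound 4 (within the scatter). Among these compounds, this is the first reading at this aromatic carbon, para to a large group, and it shows that nitro and chloro cannot be told apart there in this read-out. Nothing at hand bears on why the two groups read alike.

As far as these compounds go, whether an amine or a carboxylic acid on that carbon would shift the minimum effective dose remains open. With compounds 1, 2, 3 and 4 all level, the compounds shown also do not reveal which changes to the shared core, if any, would move it.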